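Compound 3 to compound 4: oxolan-2-yl for oxan-2-yl

The compounds below may be only part of what the source reports. "The series", "measured", "known", "first", "only" and "open" are said of these compounds alone.

Three compounds carrying an oxan-2-yl group on the shared core have been read in an ADME assay on BJ cells (Homo sapiens) for cytotoxicity, read by MTT assay, with a stated time of 72 h; on this read-out lower numbers stand for stronger inhibition and higher numbers for weaker inhibition: compound 1 (`COc1ccc(CNc2ncnc3c2ncn3C2CCCCO2)cc1OC`), compound 2 (`COc1cc(CNc2ncnc3c2ncn3C2CCCCO2)cc(OC)c1`) and compound 3 (`COc1cc(CNc2ncnc3c2ncn3C2CCCCO2)cc(OC)c1OC`). Compound 1 gives > 100000 nM, which is a limit. Compound 2 gives > 100000 nM, also a limit. Compound 3 gives > 100000 nM, again a limit, so it has no number of its own. All readings so far therefore stand at the limit of > 100000 nM in this assay, at which 3 of the 3 values shown sit.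

Compound 4 (`COc1cc(CNc2ncnc3c2ncn3C2CCCO2)cc(OC)c1OC`) differs from compound 3 in one place: oxolan-2-yl in place of oxan-2-yl on an aromatic nitrogen. Two measured steps end at compound 3: a step that the two limits leave unreadable from compound 1 to compound 3 and a step that the two limits leave unreadable from compound 2 to compound 3. Each places a methoxy in place of hydrogen on an aromatic carbon, neither has a readable size, and neither touches the group on the aromatic nitrogen. Among the measured compounds shown here, no measured step covers this swap, so no step beyond the scatter is expected in this assay, and no direction can be given. The expectation rests on compound 3, whose reading of > 100000 nM is a limit. The expected step is a number no higher from compound 3 to compound 4 (the limit leaves the size open). The estimate for compound 4 is 100000 nM, with an expected range from 40000 nM to 200000 nM.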

Compound 4, half-maximal inhibitory concentration: > 100000 nM
Compound 4: no number, only a limit; the forecaster's own chance of this, stated with the estimate: 88%; the middle value sits exactly at the limit.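

In this assay no new step can be read from compound 3 to compound 4, as both readings are limits: the limit of > 100000 nM in this assay, at which 4 of the 4 values shown sit.

Left open are the size and direction of any step for oxolan-2-yl in place of oxan-2-yl, and the concentration, if any, at which compound 1, compound 2, compound 3 or compound 4 would reach half-maximal inhibition.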